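A few compounds are considered here, and "the series" means these few. Any claim that something is new, unique, unknown or untested is made for them only; others in the source may bear on it.

Two compounds of the series have numbers in a functional assay on PANC-1 cells (Homo sapiens) for inhibition, read by MTT assay, with a stated time of 24 h, tested at 10 uM (on this read-out lower numbers stand for less inhibition and higher numbers for more inhibition at the one concentration tested (going by the name of the read-out)), so far. Compound 1 `CC(C)=CCC/C(C)=C/CC1Cc2c(OCCCOc3ccc(Cl)cc3)cc(=O)n(CCCO)c2CC1(C)C` gives 25.2% in this assay, and compound 2 `COc1ccc(NC(=O)Oc2cc(=O)n(CCCO)c3c2CC(C/C=C(\C)CCC=C(C)C)C(C)(C)C3)cc1` gives 64.1%. Within the data shown here, the one measured step, a number 38.9 percentage points higher from compound 1 to compound 2 (beyond the scatter), is the only comparison available. Compound 2 therefore stands highest of the two numbers, with compound 1 the nearest and a distance beyond the scatter between them.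

Compound 3 `COc1ccccc1NC(=O)Oc1cc(=O)n(CCCO)c2c1CC(C/C=C(\C)CCC=C(C)C)C(C)(C)C2` is the next compound. The change from compound 2 to compound 3 is 2-methoxyphenyl in place of 4-methoxyphenyl on an amide-type nitrogen. Among the measured compounds shown here, no measured step bears on this kind of change: the only recorded step alters the group on an oxygen on an aromatic ring, not the methoxyphenyl on the amide-type nitrogen. No direction can be read from the data, so the expected step in this assay is one within the scatter, a number 6.1 percentage points lower from compound 2 to compound 3 (within the scatter), with wide uncertainty around it. Compound 3 is estimated at 58%, between 35% and 78%.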

Compound 3, a percentage reported as inhibition, at one concentration (the size of the read-out at that concentration, not a potency): 53%
Estimate against measurement, compound 3: 5 percentage points above; the range from low to high includes it.
By their numbers in this assay, from the lowest: compound 1; then compound 3; then compound 2.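

In this assay the methoxyphenyl on the amide-type nitrogen is a position where the read-out responds: with the same atoms joined differently, 2-methoxyphenyl in place of 4-methoxyphenyl gives a modest step (a number 11.1 percentage points lower from compound 2 to compound 3 (beyond the scatter)). The advantage of the carbamoyl group over 3-(4-chlorophenoxy)propyl on the oxygen also holds with the 2-methoxyphenyl form (a number 27.8 percentage points higher from compound 1 to compound 3 (beyond the scatter)), so it is not confined to the 4-methoxyphenyl form. Nothing at hand explains why the two methoxyphenyl forms differ.

Open, as far as these compounds go, is how a plain phenyl or a pyridyl ring on the same nitrogen would compare with the two methoxyphenyl groups. Also open, from the compounds shown here alone, is whether an amine or a carboxylic acid on that aromatic ring would keep the number near those of compound 2 and compound 3.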